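Taking the last chloro away from compound 2

The compounds below may be only part of what the source reports. "The series", "measured", "known", "first", "only" and "open" are said of these compounds alone.

In a physicochemical assay for acid dissociation, compound 2 `Clc1ccc2[nH]c(-c3ccncc3)nc2c1` gives 3.5 and stands highest of the two measured numbers, with compound 1 `Clc1cc2nc(-c3ccncc3)[nH]c2cc1Cl` lower at 3 in the same measurement. Compound 3 `c1ccc2[nH]c(-c3ccncc3)nc2c1` differs from compound 2 by hydrogen in place of chloro on an aromatic carbon and so carries hydrogen in place of chloro on an aromatic carbon. Going by the values given here, the same exchange has been measured once, and only that modest step beyond the scatter bears on this one. Resting on a number 0.50 log units higher from compound 1 to compound 2 (beyond the scatter) alone, a step of like size in the same direction is expected in this assay here. The estimated step is a number 0.50 log units higher from compound 2 to compound 3 (beyond the scatter) on this single precedent. For compound 3 the estimate is 4 with an expected range from 3.6 to 4.5 for the measurement.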

Compound 3, acid dissociation constant: 3.85
Beside the measured number, compound 3's estimate is 0.15 log units above it; measured number inside the range.
By their numbers in this assay, from the lowest: compound 1; then compound 2; then compound 3.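

In this assay, exchanging the last chloro on the aromatic carbon for hydrogen gives a number 0.35 log units higher from compound 2 to compound 3 (beyond the scatter), leaving the core without any chloro. This modest step runs in the same direction as a number 0.50 log units higher from compound 1 to compound 2 (beyond the scatter), so the exchange now has two measured cases that agree in direction. No available evidence explains this shift. The compounds shown leave open how a methoxy group or an amine on this aromatic carbon would compare with chloro and hydrogen.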